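A few compounds are considered here, and "the series" means these few. Any claim that something is new, unique, unknown or untested is made for them only; others in the source may bear on it.

Measured in a functional assay on cells (Lymphocyte, Homo sapiens); a lower number here means a stronger inhibitor, a higher number a weaker inhibitor:
compound 1, `Nc1nc(N2CCN(C(=O)OCc3ccccc3)CC2)c2nc(-c3ccc(F)cc3)sc2n1`, gives 4900 nM
compound 2, `Nc1nc(N2CCN(C(=O)COc3ccc(Cl)cc3)CC2)c2nc(CCCCc3ccc(F)cc3)sc2n1`, gives 920 nM

Of these two, compound 2 stands lowest, which in this assay means the stronger inhibitor; its nearest neighbour, compound 1, gives a clearly higher number, a gap beyond the usual scatter of repeated measurements. Among the measured compounds shown here, compound 1 and compound 2 differ in more than one place, so no single step between them can be read off.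

Compound 3, `Nc1nc(N2CCN(C(=O)COc3ccc(Cl)cc3)CC2)c2nc(-c3ccccn3)sc2n1`, is not yet measured. It is built from compound 2 by one change: pyridin-2-yl in place of 4-(4-fluorophenyl)butyl on an aromatic carbon. The 4-(4-fluorophenyl)butyl group leaves and the much smaller pyridin-2-yl group enters on the same aromatic carbon of the shared core. For the measured compounds named here, nothing among the measured compounds shows this exchange on its own, so the direction of the step cannot be taken from data. A moderate rise in the number, that is a weakening, somewhat beyond the scatter, is expected, giving an expected step of a 2.7-fold higher number from compound 2 to compound 3 (0.43 log units; beyond the scatter). Compound 3 is therefore estimated at 2500 nM, with a likely range from 600 nM to 10000 nM.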

Compound 3, half-maximal inhibitory concentration: 230 nM
For compound 3 the middle estimate is 11-fold (1.04 log units) above the measured one, and the stated range ends above it.
By their numbers in this assay, from the lowest: compound 3; then compound 2; then compound 1.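

Among the compounds shown here, this is the first single change that can be read at this position, the aromatic carbon next to the ring nitrogen and next to the ring sulfur. Putting pyridin-2-yl in place of 4-(4-fluorophenyl)butyl gives a 4.0-fold lower number from compound 2 to compound 3 (0.60 log units; beyond the scatter) in this assay and so a stronger inhibitor, which shows that, with the rest of compound 2 kept, the 4-(4-fluorophenyl)butyl group is not required for activity and a much smaller aromatic ring does better. Nothing measured here explains the gain, so it cannot be said whether the shorter group, the ring nitrogen or something else lies behind it.

The step swaps size and ring type together, and compound 1 cannot settle the matter: it carries a ring directly at this position but also differs in the group on the other side of the core, so its step to either compound cannot be read. A plain phenyl ring here would separate the effect of the ring nitrogen from that of removing the chain, while pyridin-3-yl would test where that nitrogen sits and a shorter chain such as 2-phenylethyl would show how the number follows chain length.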